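Swapping the aryl group on the ring nitrogen

The source may hold more compounds than are shown below. What is called first, only, known or untested is meant among the compounds shown, and "the series" means these compounds.

Three measured compounds share one core and differ only in the aryl group carried on a ring nitrogen. In a functional assay on PC-12 cells (Rattus norvegicus) for cytotoxicity, read by MTT assay, with stated times of 2 h and 24 h, tested at 1 uM (on this read-out lower numbers stand for a weaker effect and higher numbers for a stronger effect at the one concentration tested), compound 1 `Oc1cc(C(F)(F)F)ccc1-c1nc(-c2ccccc2O)n(-c2ccc(OC(F)(F)F)cc2)n1` gives 65.5%. Compound 2 `N#Cc1ccc(-n2nc(-c3ccc(C(F)(F)F)cc3O)nc2-c2ccccc2O)cc1` gives 66.6% in this assay, and compound 3 `Oc1cc(C(F)(F)F)ccc1-c1nc(-c2ccccc2O)n(-c2cccc(Cl)c2)n1` gives 72.3%. Compound 3 thus stands at the top of the three numbers, yet both other values sit within the scatter of it: the steps are a number 1.1 percentage points higher from compound 1 to compound 2 (within the scatter), a number 6.8 percentage points higher from compound 1 to compound 3 (within the scatter) and a number 5.7 percentage points higher from compound 2 to compound 3 (within the scatter), none of them beyond the scatter.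

Compound 4 `Cc1ccc(-n2nc(-c3ccc(C(F)(F)F)cc3O)nc2-c2ccccc2O)c(C)c1` differs from compound 3 by 2,4-dimethylphenyl in place of 3-chlorophenyl on an aromatic nitrogen. Among the measured compounds shown here, the steps that bear on this change are a number 6.8 percentage points higher from compound 1 to compound 3 (within the scatter) and a number 5.7 percentage points higher from compound 2 to compound 3 (within the scatter). Each of them also swaps the aryl group on that ring nitrogen, and both were within the scatter. For the measured compounds named here, no measured step gives grounds to expect more than the scatter here, so the expected step of a number 4.3 percentage points lower from compound 3 to compound 4 (within the scatter) is small and of no settled direction. Compound 4 is therefore estimated at 68% in this assay, with a range from 55% to 80%.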

Compound 4, a percentage reported as activity, at one concentration (the size of the read-out at that concentration, not a potency): 73.7%
For compound 4 the middle estimate is 5.7 percentage points below the measured one; the range from low to high includes it.
By their numbers in this assay, from the lowest: compounds 1, 2, 3 and 4 (each within the scatter of the next).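

In this assay the change to 2,4-dimethylphenyl on the aromatic nitrogen is a number 1.4 percentage points higher from compound 3 to compound 4 (within the scatter) and, measured against the other two aryl groups, a number 7.1 percentage points higher from compound 2 to compound 4 (within the scatter) and a number 8.2 percentage points higher from compound 1 to compound 4 (within the scatter). The position thus accepts an aryl group of carbon only, with 8 heavy atoms, as well as the chlorine, nitrile and trifluoromethoxy bearing ones, and none of the four compounds stands beyond the scatter of another. Nothing available explains why the number stays so level at this position.

The compounds shown leave open whether an aryl group bearing an amine or a carboxylic acid, or a longer alkyl chain on that nitrogen in place of the aryl ring, would step beyond the scatter. They also leave open how these four would compare at other concentrations.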